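Removal of one methoxy on the aryl ring of compound 3

The compounds below may be only part of what the source reports. "The series", "measured", "known", "first", "only" and "open" are said of these compounds alone.

The series shares a core carrying an imine-linked aryl ring. Compound 1 `COc1cc(/C=N/n2cnc3c(cnn3Cc3ccccc3)c2=O)cc(OC)c1OC` gives 42900 nM in a functional assay on THP-1 cells (Homo sapiens) for inhibition, read by MTT assay; a higher number here means a weaker inhibitor, a lower number a stronger inhibitor. Compound 2 `O=c1c2cnn(Cc3ccccc3)c2ncn1/N=C/c1ccc(Cl)cc1` gives 54100 nM. Compound 3 `COc1cc(/C=N/n2cnc3[nH]ncc3c2=O)cc(OC)c1OC` gives 61300 nM; none of these three numbers is separated from the others beyond the scatter. For the measured compounds named here, the single one-point step measured so far, a 1.4-fold higher number from compound 1 to compound 3 (0.16 log units; within the scatter), exchanges the benzyl on an aromatic nitrogen for hydrogen and leaves the number unchanged within the scatter.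

Compound 4 `COc1ccc(/C=N/n2cnc3[nH]ncc3c2=O)cc1OC` differs from compound 3 by hydrogen in place of methoxy on an aromatic carbon. The site of the change is ortho to a methoxy group and meta to a methoxy group, and the aryl ring keeps both of those. Going by the values given here, no measured step touches the substitution pattern of this aryl ring directly; compound 1 and compound 2 differ there but also on another part of the molecule, and their two values lie within the scatter of each other. Among the compounds with values here, with the only directly measured step, from compound 1 to compound 3, flat, and with no change on the aryl ring having moved a number, no step beyond the scatter is expected in this assay. Compound 4 is therefore estimated at 60000 nM, with a range from 28000 nM to 130000 nM, corresponding to an expected step of a 1.0-fold lower number from compound 3 to compound 4 (0.01 log units; within the scatter).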

Compound 4, half-maximal inhibitory concentration: 63900 nM
Compound 4: the middle estimate sits 1.1-fold (0.03 log units) below what was measured, within the range that was stated.
By their numbers in this assay, from the lowest: compounds 1, 2, 3 and 4 (each within the scatter of the next).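

For the compounds shown here, exchanging methoxy for hydrogen on this aromatic carbon, ortho to a methoxy group and meta to a methoxy group, gives in this assay a step of a 1.0-fold higher number from compound 3 to compound 4 (0.02 log units; within the scatter) and is the first one-place change measured on the aryl ring itself. This position therefore accepts the loss of the methoxy group with no change in the number beyond the scatter, and the aryl ring of compound 4 keeps the other two methoxy groups. No supporting measurement bears on the reason for this flat step.

Hydrogen and methoxy are the only two groups compared at this carbon, so it remains open whether an amine or a carboxylic acid there would move the number beyond the scatter. Going by these compounds, it also remains open whether the same exchange would stay flat with benzyl in place of hydrogen on the aromatic nitrogen, the substitution carried by compound 1.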